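A few compounds are considered here, and "the series" means these few. Any claim that something is new, unique, unknown or untested is made for them only; others in the source may bear on it.

Measured in a functional assay on SK-BR-3 cells (Homo sapiens) for antiproliferative activity, read by MTT assay, with a stated time of 72 h; a higher number here means a weaker inhibitor, a lower number a stronger inhibitor:

Compound 1, `Cc1cc(NCCN(C)C)nc2ccc(NC(=O)c3ccc(Cl)c(Cl)c3)cc12`, gives 6670 nM.
Compound 2, `CCN1CCN(c2cc(C)c3cc(NC(=O)c4ccc(Cl)cc4)ccc3n2)CC1`, gives 3020 nM.

Of these two numbers, compound 2 holds the lower one, and its gap to compound 1 is beyond the usual scatter of this assay, so compound 2 is the stronger inhibitor of the pair. The two compounds differ in more than one place, so no single structural step can be read from that gap; only the two values themselves are known.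

Compound 3, `CCN1CCN(c2cc(C)c3cc(NC(=O)c4ccccc4Cl)ccc3n2)CC1`, shares its whole skeleton with compound 2 and differs from it in a single place: 2-chlorophenyl in place of 4-chlorophenyl on a carbonyl carbon. The chlorine stays on the ring that sits on the carbonyl carbon, but it has moved to another position on that ring.

For the measured compounds named here, no measured pair shows what such a move does on this core, so the expectation for compound 3 rests only on compound 2 as the starting point. The step from compound 2 to compound 3 is expected to be small, a 1.5-fold higher number from compound 2 to compound 3 (0.17 log units; within the scatter), most likely within or just beyond the scatter and leaning toward a weaker inhibitor. Compound 3 is therefore estimated to give about 4500 nM in this assay, with a plausible range from 1500 nM to 13000 nM.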

Compound 3, half-maximal inhibitory concentration: > 50000 nM
Compound 3 gave a limit, no number; the forecaster's own chance of this, stated with the estimate: 10%; middle value at least 11-fold (1.04 log units) away from the limit.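

Compound 2 and compound 3 hold the same atoms joined differently, so this pair isolates the place of the chlorine on the ring carried by the carbonyl carbon, which nothing earlier could show. Replacing 4-chlorophenyl with 2-chlorophenyl gives an at least 16-fold higher number from compound 2 to compound 3 (1.21 log units; beyond the scatter) in this assay, a large step, so the chlorine's place alone, with no atom added or lost, separates a compound with a measured value from one without. Compound 3 gives a limit and not a number, so the size of this step is only a bound: the limit of > 50000 nM in this assay, at which 1 of the 3 values shown sits.

The values show how large the effect of this move is, but not why it occurs, and they cannot say whether the loss belongs to chlorine itself or to any group at that place, which a methyl or methoxy group in place of the chlorine, or a plain phenyl ring, would help to separate. As far as these compounds go, it also remains open whether the same move has a similar effect when the ethylpiperazine of compound 2 is replaced by the dimethylaminoethylamine chain of compound 1.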